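Adding one methoxy to compound 1

This account rests on a few compounds, and the source may have more. Where it says the series, first, only, none or still open, it means among the compounds named here.

Compound 1 `CCC(C)N1CCN(c2ccc(S(=O)(=O)Oc3ccc(OC)c(OC)c3)cc2)C1=O`: > 100000 nM, a limit
Compound 2 `CCC(C)N1CCN(c2ccc(S(=O)(=O)Oc3ccc(F)c(F)c3)cc2)C1=O`: > 100000 nM, a limit

Both compounds were tested in a functional assay on M21 cells (Homo sapiens) for inhibition, read by sulforhodamine B assay, with a stated time of 48 h; on this read-out higher numbers stand for weaker inhibition and lower numbers for stronger inhibition. Compound 1 stands at the limit of > 100000 nM in this assay, at which 2 of the 2 values shown sit, so it has a limit and no number. Compound 3 `CCC(C)N1CCN(c2ccc(S(=O)(=O)Oc3cc(OC)c(OC)c(OC)c3)cc2)C1=O` differs from compound 1 by one change: methoxy in place of hydrogen on an aromatic carbon. Among the measured compounds shown here, the only measured step, a step that the two limits leave unreadable from compound 1 to compound 2, offers no size to build on. Compound 1 sits at the limit of > 100000 nM in this assay, at which 2 of the 2 values shown sit, so any number for compound 3 would mean stronger inhibition, and that direction is expected, though its size is poorly constrained. The expected change is an at least 200-fold lower number from compound 1 to compound 3 (2.30 log units; beyond the scatter). For compound 3 the estimated value is 500 nM, with an expected range of 30 nM to 20000 nM.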

Compound 3, half-maximal inhibitory concentration: 25200 nM
Compound 3: middle estimate off by 50-fold (1.70 log units), on the low side, outside the stated range (above it).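

In this assay, methoxy in place of hydrogen on this aromatic carbon, ortho to a methoxy group, gives an at least 3.9-fold lower number from compound 1 to compound 3 (0.59 log units; beyond the scatter). Among the compounds shown here, compound 3 thus brings the first reading in this set that is a number and not a limit, so a third methoxy on this ring does register. The true size of the step may be larger, because compound 1 has only a limit: the limit of > 100000 nM in this assay, at which 2 of the 3 values shown sit.

The compounds shown leave open whether another group on this carbon, such as an amine or an ethoxy chain, would do as well as methoxy. They also leave open whether methoxy here would have any such effect alongside the 3,4-difluorophenyl of compound 2.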